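A few compounds are considered here, and "the series" means these few. Any claim that something is new, unique, unknown or untested is made for them only; others in the source may bear on it.

Of the compounds shown here, two have so far been measured in a functional assay on Hep 3B2 cells (Homo sapiens) for antiproliferative activity, read by MTT assay, with a stated time of 24 h, tested at 0.41 ug/mL; a higher number here means a stronger effect of the compound at the concentration tested, a lower number a weaker effect. Compound 1 `CCc1ccc2nc(C(=O)Nc3c(F)cc(-c4cccc(F)c4)cc3F)c(C)c(O)c2c1` gives 16.2% in this assay. Compound 2 `Cc1ccc2nc(C(=O)Nc3c(F)cc(-c4cccc(F)c4)cc3F)c(C)c(C(=O)O)c2c1` gives 15.2% in this assay, a value that lies within the usual scatter of the value of compound 1, so the two cannot be told apart on these numbers. Compound 3 `CCc1ccc2nc(C(=O)Nc3c(F)cc(-c4cccc(F)c4)cc3F)c(C)c(C(=O)O)c2c1` has not yet been measured. It differs from compound 2 in a single place: methyl in place of hydrogen on a saturated chain carbon bound to an aromatic carbon. Compound 1 already carries the ethyl chain that this change produces, and its value and that of compound 2 agree within the scatter, so nothing in the data points to a step beyond the scatter in either direction. Close to the value of compound 2, the estimate for compound 3 is 16%, with a range from 5% to 28%. The step this estimate means, a number 0.8 percentage points higher from compound 2 to compound 3 (within the scatter), is expected to stay within the scatter.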

Compound 3, a percentage reported as inhibition, at one concentration (the size of the read-out at that concentration, not a potency): 1.68%
For compound 3 the middle estimate is 14.3 percentage points above the measured one, outside the stated range (below it).
By their numbers in this assay, from the lowest: compound 3; then compounds 2 and 1 (each within the scatter of the next).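

In this assay, going from methyl to ethyl on a saturated chain carbon bound to an aromatic carbon is not a neutral change once the carboxy group is present (a number 13.5 percentage points lower from compound 2 to compound 3 (beyond the scatter)). With the ethyl chain kept, carboxy in place of hydroxy on an aromatic carbon also matters (a number 14.5 percentage points lower from compound 1 to compound 3 (beyond the scatter)), so in these compounds each of the two changes counts only alongside the other group, and the ethyl chain cannot be judged apart from its partner. No measurement shown here explains this drop.

The compounds shown leave open whether a longer chain, such as propyl, would behave like ethyl in the presence of the carboxy group. They also leave open whether an amine or a methyl ester in place of the carboxy group would give a low number with the ethyl chain.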